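From fluoro to trifluoromethyl on a shared core

The source may report more compounds than this note shows. Statements on the series, on what has been measured and on what is new or still open speak of the compounds shown alone.

In a functional assay on HeLa cells (Homo sapiens) for inhibition (on this read-out lower numbers stand for stronger inhibition and higher numbers for weaker inhibition), compound 1 `O=C/C=C/n1ccc(=O)[nH]c1=O` gives 30000 nM and compound 2 `O=C/C=C/n1cc(F)c(=O)[nH]c1=O` gives 60000 nM on the same read-out. These two values lie within the scatter of each other, so compound 2 stands level with compound 1. Compound 3 `O=C/C=C/n1cc(C(F)(F)F)c(=O)[nH]c1=O` is still unmeasured and differs from compound 2 in one place: trifluoromethyl in place of fluoro on an aromatic carbon which amounts to trifluoromethyl in place of fluoro on an aromatic carbon. Going by the values given here, one measured step bears on this change, on that same aromatic carbon: a 2.0-fold higher number from compound 1 to compound 2 (0.30 log units; within the scatter) for fluoro in place of hydrogen, and it stays within the scatter. Among the compounds with values here, no compound with trifluoromethyl has been measured yet, so the evidence is thin and no step beyond the scatter is expected in this assay here. The expected step is a 1.2-fold lower number from compound 2 to compound 3 (0.08 log units; within the scatter) within the scatter. Compound 3 is expected near 50000 nM with an estimated range from 15000 nM to 150000 nM on this read-out.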

Compound 3, half-maximal inhibitory concentration: 60000 nM
The estimate for compound 3 lay 1.2-fold (0.08 log units) below the measured number; low and high end bracket the measured number.
By their numbers in this assay, from the lowest: compounds 1, 2 and 3 (each within the scatter of the next).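

In this assay this aromatic carbon now carries a group of 4 heavy atoms instead of 1, and putting trifluoromethyl in place of fluoro gives no change at the digits printed from compound 2 to compound 3 (within the scatter) on the shared core. Trifluoromethyl in place of hydrogen gives a 2.0-fold higher number from compound 1 to compound 3 (0.30 log units; within the scatter) as well, so hydrogen, fluoro and trifluoromethyl all stand level at this place, and the larger group brings no step beyond the scatter. No measurement on hand explains why these three values stay level.

The compounds shown leave open whether a group of another kind on this carbon, such as an amine, a carboxylic acid or a longer chain, would move the number beyond the scatter. They also leave open how much the 2-formylethenyl group, which stays the same in all three, contributes to the read-out.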